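The source may report more compounds than this note shows. Statements on the series, on what has been measured and on what is new or still open speak of the compounds shown alone.

Compound 1, `Cc1cc(CN2CCN(c3ccccc3)CC2)c(C)n1-c1ccc(Cl)cc1`, is the weaker growth inhibitor of the two compounds examined in an ADME assay on THP-1 cells (Homo sapiens) for cytotoxicity, read by trypan blue exclusion, with a stated time of 48 h; a higher number here means a weaker inhibitor of growth, a lower number a stronger inhibitor of growth: in this assay compound 1 gives 25 ug/mL, the lowest of the two numbers. Within the data shown here, its nearest neighbour is compound 2, `Cc1c(CN2CCN(c3ccccc3)CC2)cc(-c2ccc(Cl)cc2)n1-c1ccc(Cl)cc1`, which gives 294 ug/mL in this assay; the only measured step, a 12-fold higher number from compound 1 to compound 2 (1.07 log units; beyond the scatter), comes from a 4-chlorophenyl in place of methyl on an aromatic carbon.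

Compound 3, `Cc1cc(CN2CCN(C3CCCCC3)CC2)c(C)n1-c1ccc(Cl)cc1`, has not yet been measured in this assay. It differs from compound 1 in one place: cyclohexyl in place of phenyl on an amine nitrogen in a ring. Among the measured compounds shown here, no measured step touches this position, so the size of the step from compound 1 to compound 2 cannot be carried over; it concerns a different part of the shared core and a different kind of change. With nothing to point in either direction, compound 3 is expected to stay close to compound 1 in this assay, with an estimated step of no change at the digits printed from compound 1 to compound 3 (within the scatter) that lies within the scatter. Compound 3 is therefore estimated at 25 ug/mL in this assay, within a range from 10 ug/mL to 60 ug/mL.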

Compound 3, concentration for 50% growth inhibition: 16 ug/mL
For compound 3 the middle estimate is 1.6-fold (0.19 log units) above the measured one, within the range that was stated.
By their numbers in this assay, from the lowest: compounds 3 and 1 (each within the scatter of the next); then compound 2.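

In this assay the position on the amine nitrogen in a ring now has a measured step of its own: cyclohexyl in place of phenyl gives a 1.6-fold lower number from compound 1 to compound 3 (0.19 log units; within the scatter) and so leaves compound 3 and compound 1 indistinguishable in this read-out. The two groups have the same count of heavy atoms and neither carries a hydrogen-bond donor or acceptor, so the change amounts to a non-aromatic ring of carbon standing where an aromatic one stood, and at this position, in this one pair, that exchange does not move the number beyond the scatter. This differs from the only earlier step, a 12-fold higher number from compound 1 to compound 2 (1.07 log units; beyond the scatter) at an aromatic carbon elsewhere on the shared core, which is the one change shown so far that goes beyond the scatter. No measurement offered here accounts for either step.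

The compounds shown leave open whether a group of another kind on the same amine nitrogen, such as a benzyl group, an acetyl group or a chain ending in a carboxylic acid, would stay as close to compound 1 as cyclohexyl does. They also leave open whether cyclohexyl at this position would read the same alongside the 4-chlorophenyl of compound 2.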